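Working notes: difluoromethyl for butyl on the ring oxygen

The source may hold more compounds than are shown below. What is called first, only, known or untested is meant among the compounds shown, and "the series" means these compounds.

Compound 1 `CCCCOc1ccc(Nc2nc3nonc3nc2O)cc1`: compound 1 gives 3700 nM in an assay on mitochondria from L6 cells (Rattus norvegicus) for activation, with a stated time of 90 min; on this read-out higher numbers stand for an effect only at larger amounts of compound and lower numbers for an effect already at smaller amounts.
Compound 2 `CCc1cccc(Nc2nc3nonc3nc2O)c1`: compound 2 gives 25200 nM in this assay.
Compound 3 `Oc1nc2nonc2nc1Nc1ccccc1Cl`: compound 3 gives 6300 nM in this assay.

Three measured compounds share one core and differ only in the substituted phenyl attached through the amine nitrogen. Compound 1 carries the lowest number of the three. Its nearest neighbour is compound 3, whose value lies within the usual scatter of compound 1, so the two cannot be ordered against each other. Compound 2 stands apart from compound 1 beyond the scatter. Going by the values given here, no pair of measured compounds differs in a single place, so no measured step exists that could be carried over to the new compound.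

Compound 4 `Oc1nc2nonc2nc1Nc1ccc(OC(F)F)cc1` differs from compound 1 by difluoromethyl in place of butyl on an oxygen on an aromatic ring. The oxygen on the ring and its attachment stay; only the group on that oxygen changes. Among the compounds with values here, with no matched step to lean on, the expectation for compound 4 rests on the value of compound 1, 3700 nM. A step of a 1.4-fold higher number from compound 1 to compound 4 (0.13 log units; within the scatter) is expected, small and toward a larger number, at the edge of the scatter. Compound 4 is estimated at 5000 nM, with a range from 1500 nM to 15000 nM in this assay.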

Compound 4, half-maximal effective concentration: 20600 nM
The estimate for compound 4 lay 4.1-fold (0.61 log units) below the measured number; the whole stated range lies below it.
By their numbers in this assay, from the lowest: compounds 1 and 3 (each within the scatter of the next); then compounds 4 and 2 (each within the scatter of the next).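

In this assay the group on the ring oxygen proves not to be neutral to the read-out: difluoromethyl in place of butyl brings a 5.6-fold higher number from compound 1 to compound 4 (0.75 log units; beyond the scatter) and gives the series its first step that rests on a single place. The earlier compounds shown here could not show this, since they differ from one another in more than one place and offered no direct view of the group on this oxygen. On this core, then, butoxy and difluoromethoxy are not interchangeable, and the number moves toward larger amounts of compound in going from the butyl chain to the difluoromethyl group, though no measurement at hand accounts for the size of this step.

Going by these compounds, this single step changes chain length and brings in fluorine at once, so the share of each stays open; methoxy, and a butyl chain carrying fluorine, on the same oxygen would separate the two. Also open, on these data alone, is how far the trend runs in the other direction, with a longer chain such as hexyl on the oxygen, and whether an amine in place of the ring oxygen would keep the value of compound 1.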